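The compounds below may be only part of what the source reports. "The series", "measured", "known", "first", "only" and "open" are said of these compounds alone.

Compound 1 `CC[N+]1(CCCCCCCOc2cc(-n3cc(C(=O)Nc4cc(F)cc(F)c4)c(=O)c4ccc(N(C)C)nc43)ccc2C)CCCC1` and compound 2 `CC[N+]1(CCCCCCCOc2cc(-n3cc(C(=O)Nc4cc(F)cc(F)c4)c(=O)c4ccc(N(C)C)nc43)ccc2Cl)CCCC1` share one core. In an assay on LX2 cells for inhibition of COL1A1 promoter (Homo sapiens), read by a luciferase reporter, with a stated time of 24 h, tested at 20 uM (a higher number here means a stronger effect of the compound at the concentration tested, a lower number a weaker effect), compound 1 gives 57%, while compound 2 gives 46%. The step of a number 11 percentage points lower from compound 1 to compound 2 (beyond the scatter) comes from one change, (chloro in place of methyl on an aromatic carbon).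

Compound 3 `Cc1cc(OCCCCCCC[N+](C)(C)C2CCCCC2)ccc1-n1cc(C(=O)Nc2cc(F)cc(F)c2)c(=O)c2ccc(N(C)C)nc21` carries a different core; the difference between the two cores is not broken down here. In this assay compound 3 is reported as "not active" (no number reported). Compound 4 `CN(C)c1ccc2c(=O)c(C(=O)Nc3cc(F)cc(F)c3)cn(-c3ccc(OCCCCCCC[N+](C)(C)C4CCCCC4)cc3Cl)c2n1` is made from compound 3 by chloro in place of methyl on an aromatic carbon. This is the same kind of change as that from compound 1 to compound 2, though not the same: in compound 2 the place is para to a large group, in compound 4 it is meta to a large group.

Since compound 3 shows no activity and the earlier step was modest and downward, compound 4 is expected to remain weak, estimated at 10% with a range from 0% to 30%.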

Compound 4, a percentage reported as inhibition, at one concentration (the size of the read-out at that concentration, not a potency): "not active" (no number reported)
The entry for compound 4 holds no number; there is nothing to compare the estimate with.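

In this assay, among these compounds, compound 3 gives "not active" (no number reported) and compound 4 gives "not active" (no number reported) and so no step between them can be read. The two compounds leave open whether chloro in place of methyl changes anything on this core. No evidence shown here bears on this result.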